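Halogen swap on the formyl-bearing analogue

The source may hold more compounds than are shown below. What is called first, only, known or untested is meant among the compounds shown, and "the series" means these compounds.

Measured so far in a functional assay on the whole organism (strain Wistar albino) for inhibition, with Rattus norvegicus as the target, read by paw edema, with a stated time of 0.5 h, at a dose of 100 mg/kg by the oral route; a lower number here means less inhibition, a higher number more inhibition at the dose given (going by the name of the read-out):
compound 1 `Cc1ccc2c(Cc3nn4cc(-c5ccc(Cl)cc5)nc4s3)coc2c1` gives 8.38%
compound 2 `Cc1ccc2c(Cc3nn4cc(-c5ccc(Br)cc5)nc4s3)coc2c1` gives 6%
compound 3 `Cc1ccc2c(Cc3nn4c(C=O)c(-c5ccc(Cl)cc5)nc4s3)coc2c1` gives 3.6%

Compound 3 holds the lowest of the three numbers, but its gap to compound 2 and to compound 1 is within the scatter, so none of the three can be set apart from the others. The step of a number 4.8 percentage points lower from compound 1 to compound 3 (within the scatter) is within the scatter, and so is a number 2.4 percentage points lower from compound 1 to compound 2 (within the scatter).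

Compound 4 `Cc1ccc2c(Cc3nn4c(C=O)c(-c5ccc(Br)cc5)nc4s3)coc2c1` is not yet measured. It differs from compound 3 as follows: bromo in place of chloro on an aromatic carbon. Going by the values given here, the only step that bears directly on this change is the one from compound 1 to compound 2, where the same bromo-for-chloro exchange on the shared core without the formyl group gave a number 2.4 percentage points lower from compound 1 to compound 2 (within the scatter), within the scatter. Among the compounds with values here, with only that step as guide, no move beyond the scatter is expected in this assay; the estimated step is a number 1.1 percentage points lower from compound 3 to compound 4 (within the scatter). Compound 4 is therefore expected to give about 2.5%, with a range from 0% to 8%.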

Compound 4, a percentage reported as inhibition, in the whole organism at one dose (the size of the read-out at that dose, not a potency): 1.15%
Beside the measured number, compound 4's estimate is 1.4 percentage points above it, within the range that was stated.
By their numbers in this assay, from the lowest: compounds 4, 3, 2 and 1 (each within the scatter of the next).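

In this assay, the change from 4-chlorophenyl to 4-bromophenyl on the formyl-bearing core gives a number 2.5 percentage points lower from compound 3 to compound 4 (within the scatter), so this exchange can now be read on two cores, and the two readings agree: the same change on two cores in this assay, a number 2.4 percentage points lower (within the scatter) from compound 1 to compound 2 and a number 2.5 percentage points lower (within the scatter) from compound 3 to compound 4, 0.1 percentage points apart, within the scatter of two such steps Formyl in place of hydrogen, until now read only with the chloro group, gives a number 4.9 percentage points lower from compound 2 to compound 4 (within the scatter) with the bromo group, and this also matches the earlier step: the same change on two cores in this assay, a number 4.8 percentage points lower (within the scatter) from compound 1 to compound 3 and a number 4.9 percentage points lower (within the scatter) from compound 2 to compound 4, 0.1 percentage points apart, within the scatter of two such steps Each change stays within the scatter on both cores, so neither is shown to shift the read-out in this assay.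

Still open, going by these compounds, is whether any group at these two places moves the number beyond the scatter. An amine or a carboxylic acid in place of the formyl group would test this, as would a methoxy group in place of the bromo.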